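Replacing a chloro-aryl amide with a short alkyl chain

A few compounds are considered here, and "the series" means these few. Any claim that something is new, unique, unknown or untested is made for them only; others in the source may bear on it.

Of the compounds shown here, three sharing one core have been tested in a functional assay on NUGC-3 cells (Homo sapiens) for cytotoxicity, read by sulforhodamine B assay, with a stated time of 72 h; a lower number here means a stronger inhibitor of growth, a higher number a weaker inhibitor of growth. Compound 1, `CCCCCCCCC(=O)N1c2ccccc2CCC1C(=O)Nc1ccccc1C(F)(F)F`, gives 6180 nM. Compound 2, `O=C(Nc1ccccc1C(F)(F)F)C1CCc2ccccc2N1C(=O)c1ccccc1Cl`, gives 2730 nM, and the step between them is a 2.3-fold lower number from compound 1 to compound 2 (0.35 log units; beyond the scatter). Compound 3, `O=C(Nc1ccccc1O)C1CCc2ccccc2N1C(=O)c1ccccc1Cl`, gives 36800 nM, with the step of a 13-fold higher number from compound 2 to compound 3 (1.13 log units; beyond the scatter). Compound 2 therefore stands lowest of the three numbers, beyond the scatter of both neighbours.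

Compound 4, `CCCC(=O)N1c2ccccc2CCC1C(=O)Nc1ccccc1C(F)(F)F`, differs from compound 2 in one place: propyl in place of 2-chlorophenyl on a carbonyl carbon. Among the measured compounds shown here, the only measured step that touches this position is the one from compound 1 to compound 2, where a 2-chlorophenyl replaced an octyl on the same carbonyl carbon and the number fell modestly, by a 2.3-fold lower number from compound 1 to compound 2 (0.35 log units; beyond the scatter). Compound 4 goes back from the 2-chlorophenyl to an alkyl chain, though a shorter one than in compound 1, so a modest rise in the number is the natural expectation, with no measured guide to how much the chain length itself matters. The step from compound 2 to compound 3 concerns the other end of the molecule and does not bear on this change.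

Compound 4 is therefore expected to give about 6000 nM, within a range from 2500 nM to 15000 nM. This expectation amounts to a step of a 2.2-fold higher number from compound 2 to compound 4 (0.34 log units; beyond the scatter).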

Compound 4, concentration for 50% growth inhibition: > 70000 nM
Compound 4 ended at the assay's limit (the forecaster's own chance of this, stated with the estimate: 5%); at least 11-fold (1.06 log units) between middle value and limit.
By their numbers in this assay, from the lowest: compound 2; then compound 1; then compound 3. At a limit, above all of these: compound 4.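

In this assay compound 4 reaches a limit of the assay, not a measured number: the limit of > 70000 nM in this assay, at which 1 of the 4 values shown sits.

Even read against that limit, the position on a carbonyl carbon whose other neighbour is the amide-type nitrogen in a ring proves far less forgiving than the earlier compounds showed, since putting propyl in place of 2-chlorophenyl gives an at least 25-fold higher number from compound 2 to compound 4 (1.40 log units; beyond the scatter), a much larger change than the modest one seen in a 2.3-fold lower number from compound 1 to compound 2 (0.35 log units; beyond the scatter). Alkyl chains at this position are also not interchangeable: shortening octyl to propyl gives an at least 11-fold higher number from compound 1 to compound 4 (1.05 log units; beyond the scatter), so a long chain keeps a measurable effect on growth here while the short one does not.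

The compounds shown leave open where between propyl and octyl the number begins to climb, a question that a pentyl or hexyl chain on the same carbonyl carbon would answer. They also leave open whether the chlorine of the 2-chlorophenyl group contributes to the lower number of compound 2, which a plain phenyl group at this position would test.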